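The source may hold more compounds than are shown below. What is called first, only, known or untested is meant among the compounds shown, and "the series" means these compounds.

Of the compounds shown here, three sharing one core have been tested in a functional assay on DU-145 cells (Homo sapiens) for inhibition, read by trypan blue exclusion, with a stated time of 96 h; on this read-out lower numbers stand for stronger inhibition of growth and higher numbers for weaker inhibition of growth. Compound 1 `Cc1ccc(CS(=O)(=O)/C(=C/c2ccc(Br)cc2)C(=O)c2ccc(Cl)cc2)cc1` gives 25000 nM in this assay. Compound 2 `Cc1ccc(CS(=O)(=O)/C(=C/c2cc(C)cc(C)c2)C(=O)c2ccc(Cl)cc2)cc1` gives 10000 nM in this assay. Compound 3 `Cc1ccc(CS(=O)(=O)/C(=C/c2ccccc2Br)C(=O)c2ccc(Cl)cc2)cc1` gives 25000 nM in this assay. The change from compound 1 to compound 2 is a 2.5-fold lower number from compound 1 to compound 2 (0.40 log units; beyond the scatter), the change from compound 1 to compound 3 is no change at the digits printed from compound 1 to compound 3 (within the scatter), and from compound 2 to compound 3 it is a 2.5-fold higher number from compound 2 to compound 3 (0.40 log units; beyond the scatter). Compound 2 thus has the lowest number of the three, and both of its steps to the other compounds lie beyond the scatter.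

Compound 4 `Cc1ccc(S(=O)(=O)/C(=C/c2cc(C)cc(C)c2)C(=O)c2ccc(Cl)cc2)cc1` differs from compound 2 in one place: 4-methylphenyl in place of 4-methylbenzyl on a sulfonyl sulfur. Going by the values given here, all three measured steps alter the aromatic ring on the double-bonded chain carbon, and none touches the group on the sulfonyl sulfur, so no measured step bears directly on this change. The measured steps were at most modest, and nothing in these data suggests that this change should move the number far. Compound 4 is therefore expected to give roughly the number of compound 2, the estimated step being no change at the digits printed from compound 2 to compound 4 (within the scatter). The estimate for compound 4 in this assay is 10000 nM, with an expected range from 4000 nM to 30000 nM.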

Compound 4, concentration for 50% growth inhibition: 1000 nM
For compound 4 the middle estimate is 10-fold (1.00 log units) above the measured one; the measured number lies below the stated range.
By their numbers in this assay, from the lowest: compound 4; then compound 2; then compounds 1 and 3 (each within the scatter of the next).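

In this assay, the group on the sulfonyl sulfur turns out to be a place where the number responds strongly: 4-methylphenyl in place of 4-methylbenzyl gives a 10-fold lower number from compound 2 to compound 4 (1.00 log units; beyond the scatter) and this step is larger than a 2.5-fold lower number from compound 1 to compound 2 (0.40 log units; beyond the scatter) among the changes to the aromatic ring on the double-bonded chain carbon. The change itself is small on paper, since both groups hold one six-membered aromatic ring of carbon only and neither has hydrogen-bond donors or acceptors, while 4-methylbenzyl has 8 heavy atoms and 4-methylphenyl has 7. Nothing in the information available accounts for the size of this step.

Going by these compounds alone, this step has been seen only with 3,5-dimethylphenyl on the double-bonded chain carbon, so it remains open whether the same exchange would lower the number as far with 4-bromophenyl or 2-bromophenyl in that place. Also open, on these data alone, is how the number would respond to other groups on the sulfonyl sulfur, such as an unsubstituted phenyl, a plain methyl or a longer chain like 2-phenylethyl.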